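The source may report more compounds than this note shows. Statements on the series, on what has been measured and on what is new or still open speak of the compounds shown alone.

Going by the values given here, in a functional assay on ECa-109 cells for inhibition, with ECa-109 cell line (Homo sapiens) as the target, read by sulforhodamine B assay (a higher number here means a weaker inhibitor, a lower number a stronger inhibitor), compound 3 `O=C1C=C(Nc2ccc(I)cc2)C(=O)c2c1nc1n2[C@H]2OC[C@@H](O)[C@H]2OC1` gives 2300 nM as the only actual number. Compound 1 `CCCc1ccc(NC2=CC(=O)c3nc4n(c3C2=O)[C@H]2OC[C@@H](O)[C@H]2OC4)cc1` is reported only as a limit, > 4000 nM in this assay. Compound 2 `CCCN(CCC)C1=CC(=O)c2nc3n(c2C1=O)[C@H]1OC[C@@H](O)[C@H]1OC3` is likewise reported only as a limit, > 16000 nM in this assay. Compound 4 `COc1cccc(NC2=CC(=O)c3nc4n(c3C2=O)[C@H]2OC[C@@H](O)[C@H]2OC4)c1` differs from compound 3 by 3-methoxyphenyl in place of 4-iodophenyl on an amine nitrogen with 3-methoxyphenyl in place of 4-iodophenyl on an amine nitrogen. Compound 4 keeps an aromatic ring on that nitrogen, so the nearer guide is an at least 1.7-fold lower number from compound 1 to compound 3 (0.24 log units; that floor lies within the scatter) with iodo in place of propyl, rather than an at least 6.9-fold lower number from compound 2 to compound 3 (0.84 log units; beyond the scatter) with (4-iodophenyl)amino in place of dipropylamino. An estimated 1.7-fold higher number from compound 3 to compound 4 (0.24 log units; within the scatter) is therefore expected, toward a higher number but within the scatter. Compound 4 is expected at 4000 nM in this assay, with an estimated range of 1400 nM to 12000 nM.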

Compound 4, half-maximal inhibitory concentration: 7620 nM
Beside the measured number, compound 4's estimate is 1.9-fold (0.28 log units) below it, and the stated range covers the measured number.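

Going by these compounds alone, with an aromatic ring kept on the amine nitrogen, 3-methoxyphenyl in place of 4-iodophenyl gave a 3.3-fold higher number from compound 3 to compound 4 (0.52 log units; beyond the scatter), the first step between two actual numbers in this assay. A second arylamino group also separated from dipropylamino, with an at least 2.0-fold lower number from compound 2 to compound 4 (0.32 log units; beyond the scatter). The step between compound 1 and compound 4 cannot be read.

As far as these compounds go, whether the step in the aryl series follows the loss of iodo or the entry of methoxy stays open, as the two change together. From the compounds shown here alone, how a phenyl ring carrying a carboxylic acid or an amine would read here is also open.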